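Compound 1 to compound 4: one group exchanged

A few compounds are considered here, and "the series" means these few. Any claim that something is new, unique, unknown or untested is made for them only; others in the source may bear on it.

Measured in a functional assay on HCT-116 cells (Homo sapiens) for antiproliferative activity, read by MTT assay, with a stated time of 72 h; on this read-out lower numbers stand for stronger inhibition of growth and higher numbers for weaker inhibition of growth:
Compound 1 `COc1cc(OC)c(/C=C/S(=O)(=O)Cc2cnc(OC)cn2)c(OC)c1`: 950 nM
Compound 2 `CCOc1cc(OC)cc(OC)c1/C=C/S(=O)(=O)Nc1ccc(OC)nc1`: 420 nM
Compound 3 `COc1cc(OC)c(/C=C/S(=O)(=O)Nc2ccc(Cl)cc2)c(OC)c1`: > 10000 nM (a limit)

Of the two actual numbers in this assay, compound 1 holds the higher, 950 nM, and compound 2 the lower, 420 nM. The entry for compound 3 is a limit, > 10000 nM, and not a number.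

Compound 4 `COc1cc(OC)c(/C=C/S(=O)(=O)Cc2nc(N)ncc2OC)c(OC)c1` differs from compound 1 (2-amino-5-methoxypyrimidin-4-yl in place of 5-methoxypyrazin-2-yl on a saturated chain carbon bound to a sulfonyl sulfur), with 2-amino-5-methoxypyrimidin-4-yl in place of 5-methoxypyrazin-2-yl on a saturated chain carbon bound to a sulfonyl sulfur. Among the measured compounds shown here, no measured pair shows this exchange, so the range stays wide. The expected change is a 1.9-fold lower number from compound 1 to compound 4 (0.28 log units; within the scatter), a modest move toward stronger inhibition of growth that is not expected to clear the scatter. For compound 4 the estimate is 500 nM, with an expected range from 60 nM to 4000 nM.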

Compound 4, concentration for 50% growth inhibition: > 10000 nM
Compound 4: no number, only a limit (the forecaster's own chance of this, stated with the estimate: 10%); at least 20-fold (1.30 log units) between middle value and limit.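

In this assay, 2-amino-5-methoxypyrimidin-4-yl in place of 5-methoxypyrazin-2-yl on a saturated chain carbon bound to a sulfonyl sulfur gives an at least 10-fold higher number from compound 1 to compound 4 (1.02 log units; beyond the scatter), a large step beyond the scatter. Compound 4 gives > 10000 nM, which is a limit and not a number. This is the first step shown at this position, and it shows that inhibition of growth depends strongly on the group held there, though its full size stays unknown: the limit of > 10000 nM in this assay, at which 2 of the 4 values shown sit.

The compounds shown leave open whether the loss follows the amine or the different ring. A 5-methoxypyrimidin-4-yl group without the amine, or a 5-methoxypyrazin-2-yl group carrying an amine, would separate the two.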